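Aryl hydrazone variation on the shared core

A few compounds are considered here, and "the series" means these few. Any claim that something is new, unique, unknown or untested is made for them only; others in the source may bear on it.

Within the data shown here, compound 1 `Cn1c(=O)c(=O)n(C2CCCC2)c2nc(N/N=C/c3ccc(O)c(F)c3)ncc21` is the one member of the series with a number in a functional assay on A549 cells (Homo sapiens) for antiproliferative activity, read by MTT assay (a lower number here means a stronger inhibitor, a higher number a weaker inhibitor), where compound 1 gives 97800 nM. Compound 2 `COc1ccc(/C=N/Nc2ncc3c(n2)n(C2CCCC2)c(=O)c(=O)n3C)c(OC)c1` reaches only the limit of this assay and is reported as > 100000 nM. Compound 3 `COc1ccc(/C=N/Nc2ncc3c(n2)n(C2CCCC2)c(=O)c(=O)n3C)cc1` also sits at the limit, reported as > 100000 nM. The steps from compound 1 are therefore floors: an at least 1.0-fold higher number from compound 1 to compound 2 (0.00 log units; that floor lies within the scatter) and an at least 1.0-fold higher number from compound 1 to compound 3 (0.00 log units; that floor lies within the scatter), both replacing 3-fluoro-4-hydroxyphenyl on a carbon with a double bond to nitrogen. On these data alone, compound 4 `Cn1c(=O)c(=O)n(C2CCCC2)c2nc(N/N=C/c3ccccc3F)ncc21` is untested; its change is 2-fluorophenyl in place of 3-fluoro-4-hydroxyphenyl on a carbon with a double bond to nitrogen. Because both measured steps away from 3-fluoro-4-hydroxyphenyl end at the limit of > 100000 nM in this assay, at which 2 of the 3 values shown sit, compound 4 is expected at or past that limit, a 1.5-fold higher number from compound 1 to compound 4 (0.19 log units; within the scatter). The estimate for compound 4 is 150000 nM, ranging from 60000 nM to 400000 nM.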

Compound 4, half-maximal inhibitory concentration: 31200 nM
The estimate for compound 4 lay 4.8-fold (0.68 log units) above the measured number, and the stated range ends above it.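

With 2-fluorophenyl on this carbon, the aryl group proves able to shift the read-out in this assay beyond the scatter, with a 3.1-fold lower number from compound 1 to compound 4 (0.50 log units; beyond the scatter). The hydroxy group of compound 1 is not required for a number of this size, as compound 4 lacks it. The methoxy-bearing compounds give only floors, an at least 3.2-fold lower number from compound 3 to compound 4 (0.50 log units; beyond the scatter) and an at least 3.2-fold lower number from compound 2 to compound 4 (0.50 log units; beyond the scatter), as each stands at a limit: the limit of > 100000 nM in this assay, at which 2 of the 4 values shown sit.

Loss of the hydroxy group and the different fluorine placement arrive in one change and cannot be separated here. On these data alone, whether an amine or a carboxylic acid on this ring would lower the number further remains open.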